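Removing the methoxy from the benzyl amide of compound 3

This account rests on a few compounds, and the source may have more. Where it says the series, first, only, none or still open, it means among the compounds named here.

Measured compounds:
- compound 1, `COc1ccc2c(=O)c(/C=C/C(=O)Nc3ccc(Cl)cc3)coc2c1`: > 100000 nM
- compound 2, `O=C(/C=C/c1coc2cc(O)ccc2c1=O)NCc1ccccc1`: 63000 nM
- compound 3, `COc1ccc(CNC(=O)/C=C/c2coc3cc(OC)ccc3c2=O)cc1`: 15700 nM

Three compounds share one core and differ in the group on the amide nitrogen or on the core. In a functional assay (QGY7701 cells, Homo sapiens) for inhibition, read by MTT assay, with a stated time of 48 h (a lower number here means a stronger inhibitor, a higher number a weaker inhibitor), compound 1 gives > 100000 nM, which is a limit of the assay rather than a number. In this assay compound 2 gives 63000 nM, and compound 3 gives 15700 nM, the lowest number of the two that were measured; its nearest neighbour is compound 2. Among the compounds with values here, the one step between compounds that differ in a single place is an at least 6.3-fold lower number from compound 1 to compound 3 (0.80 log units; beyond the scatter), which rests on (the limit of > 100000 nM in this assay, at which 1 of the 3 values shown sits).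

Compound 4, `COc1ccc2c(=O)c(/C=C/C(=O)NCc3ccccc3)coc2c1`, has not been measured. It differs from compound 3 in one place: hydrogen in place of methoxy on an aromatic carbon. Within the data shown here, no measured step changes only this group; the step from compound 1 to compound 3 swaps the whole amide substituent at once, so it cannot be separated. Compound 2 carries a plain benzyl but also a hydroxy on the core, so it shows only that a benzyl amide can sit at a weaker level. A small weakening is therefore expected, and compound 4 is estimated at 30000 nM with a range from 10000 nM to 100000 nM, meaning an expected step of a 1.9-fold higher number from compound 3 to compound 4 (0.28 log units; within the scatter).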

Compound 4, half-maximal inhibitory concentration: > 100000 nM
Compound 4: a limit, no number; the forecaster's own chance of this, stated with the estimate: 15%; middle value at least 3.3-fold (0.52 log units) from the limit.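

Taking the methoxy off the benzyl group gives an at least 6.3-fold higher number from compound 3 to compound 4 (0.80 log units; beyond the scatter) in this assay, the first step that changes this one group alone, and it shows that the 4-methoxybenzyl amide reads clearly lower than the plain benzyl amide on this core. The reading for compound 4 is a limit of the assay and not a number, so that step gives only a floor, and the step between compound 1 and compound 4 cannot be read: the limit of > 100000 nM in this assay, at which 2 of the 4 values shown sit. With the plain benzyl kept, methyl on the core oxygen gives an at least 1.5-fold higher number from compound 2 to compound 4 (0.20 log units; that floor lies within the scatter), so this pair does not settle what that change does.

The compounds shown compare only methoxy and hydrogen at this place on the benzyl ring. Going by these compounds, whether an ethoxy, an amine or a fluorine there would give a lower number remains open.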